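A few compounds are considered here, and "the series" means these few. Any claim that something is new, unique, unknown or untested is made for them only; others in the source may bear on it.

Measured so far in a functional assay on U-251 cells (Homo sapiens) for inhibition, read by sulforhodamine B assay, with a stated time of 48 h; on this read-out higher numbers stand for weaker inhibition of growth and lower numbers for stronger inhibition of growth:
- compound 1 `COc1ccc(/C=C/C2(C)C=CC(=O)O2)cc1OC`: 193000 nM
- compound 2 `COc1ccc(/C=C/C2(C)C=CC(=O)O2)c(OC)c1OC`: 87200 nM
- compound 3 `COc1cc(OC)c(OC)cc1/C=C/C1(C)C=CC(=O)O1`: 160000 nM

Compound 1 holds the highest of these numbers, but it is not clear of all of them. The nearest comparison is a 1.2-fold lower number from compound 1 to compound 3 (0.08 log units; within the scatter), and the furthest is a 2.2-fold lower number from compound 1 to compound 2 (0.35 log units; beyond the scatter).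

The unmeasured compound 4 `COc1cc(/C=C/C2(C)C=CC(=O)O2)cc(OC)c1OC` differs from compound 1 by methoxy in place of hydrogen on an aromatic carbon. This is methoxy in place of hydrogen on an aromatic carbon, ortho to a methoxy group.

The two measured steps are the same kind of change made at other places on the ring, and neither matches this place. Both point to a lower number, one modestly and one without leaving the scatter. Three compounds cannot show how much the place matters, so only a small step is expected in this assay.

The expected change is a 1.5-fold lower number from compound 1 to compound 4 (0.17 log units; within the scatter). For compound 4 the estimated value is 130000 nM, with an expected range from 65000 nM to 250000 nM.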

Compound 4, concentration for total growth inhibition: 125000 nM
The estimate for compound 4 lay 1.0-fold (0.02 log units) above the measured number, within the range that was stated.
By their numbers in this assay, from the lowest: compounds 2, 4, 3 and 1 (each within the scatter of the next, the first and the last beyond it).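

In this assay methoxy in place of hydrogen on an aromatic carbon, ortho to a methoxy group and meta to a group of 9 heavy atoms, gives a 1.5-fold lower number from compound 1 to compound 4 (0.19 log units; within the scatter) and so does not separate from compound 1 at this place. The same change gives a 1.2-fold lower number from compound 1 to compound 3 (0.08 log units; within the scatter) at another place and a 2.2-fold lower number from compound 1 to compound 2 (0.35 log units; beyond the scatter) at a third, so all three steps point the same way, but only the last leaves the scatter. No supporting measurement bears on why the places differ.

As far as these compounds go, whether a hydroxyl, an amine or a carboxylic acid at this place would move the number beyond the scatter stays open. Also open, from the compounds shown here alone, is whether a longer chain in place of the methoxy group would do so, and whether these small steps hold in other cell lines.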